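A few compounds are considered here, and "the series" means these few. Any claim that something is new, unique, unknown or untested is made for them only; others in the source may bear on it.

Compound 3 `Oc1cc(C(F)(F)F)ccc1-c1nc(-c2ccccc2O)n(-c2ccccc2F)n1` is one of three compounds tested in a functional assay on PC-12 cells (Rattus norvegicus) for cytotoxicity, read by MTT assay, with stated times of 2 h and 24 h, tested at 10 uM (a higher number here means a stronger effect of the compound at the concentration tested, a lower number a weaker effect), where compound 3 gives 100%. Compound 1 `Cc1ccc(-n2nc(-c3ccc(C(F)(F)F)cc3O)nc2-c2ccccc2O)cc1` gives 102% in this assay, and compound 2 `COc1ccc(-n2nc(-c3ccc(C(F)(F)F)cc3O)nc2-c2ccccc2O)cc1` gives 98.9%. The three numbers lie close together: the step of a number 2 percentage points lower from compound 1 to compound 3 (within the scatter) and the step of a number 1.1 percentage points higher from compound 2 to compound 3 (within the scatter) are both within the scatter, as is the step of a number 3.1 percentage points lower from compound 1 to compound 2 (within the scatter), so compound 3 sits among numbers that cannot be told apart.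

Compound 4 `Oc1cc(C(F)(F)F)ccc1-c1nc(-c2ccccc2O)n(-c2ccccc2C(F)(F)F)n1` differs from compound 3 in one place: trifluoromethyl in place of fluoro on an aromatic carbon.

For the measured compounds named here, no measured pair shows exactly this exchange. The steps that come closest are those that also alter the group on the aromatic nitrogen, namely a number 2 percentage points lower from compound 1 to compound 3 (within the scatter) and a number 1.1 percentage points higher from compound 2 to compound 3 (within the scatter), and both are within the scatter. Every change tried so far at this part of the shared core has left the read-out of this assay essentially unmoved at a high level. On that basis the expected step of no change at the digits printed from compound 3 to compound 4 (within the scatter) is no step beyond the scatter. Compound 4 is therefore estimated to give 100% in this assay, with a range from 90% to 110%.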

Compound 4, a percentage reported as activity, at one concentration (the size of the read-out at that concentration, not a potency): 92.2%
For compound 4 the middle estimate is 7.8 percentage points above the measured one, and the stated range covers the measured number.
By their numbers in this assay, from the lowest: compounds 4, 2, 3 and 1 (each within the scatter of the next).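

In this assay, trifluoromethyl, with four heavy atoms, replaces fluoro, with one, on an aromatic carbon ortho to a large group, and a number 7.8 percentage points lower from compound 3 to compound 4 (within the scatter) shows that this larger group gives a step that cannot be told from the scatter. Set against the two other groups on the aromatic nitrogen, 2-(trifluoromethyl)phenyl gives the same picture, since both a number 6.7 percentage points lower from compound 2 to compound 4 (within the scatter) and a number 9.8 percentage points lower from compound 1 to compound 4 (within the scatter) also stay within the scatter, so all four compounds remain indistinguishable in this read-out. No measurement is at hand that would explain this result or tie it to any property of these groups.

An amine or a carboxylic acid at this aromatic carbon, or a longer chain such as propyl, could still behave differently, so the tolerance seen here extends only to the groups shown. From the compounds shown here alone, it also remains open how these compounds compare at other concentrations, since a single-concentration read-out is not a measure of potency.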